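This account rests on a few compounds, and the source may have more. Where it says the series, first, only, none or still open, it means among the compounds named here.

In an ADME assay on Vero 76 cells (Chlorocebus sabaeus) for cytotoxicity, read by MTT assay, with a stated time of 96 h (on this read-out higher numbers stand for lower toxicity in this test and lower numbers for higher toxicity in this test), compound 1 (`Brc1ccc(NCc2cn(-c3ccccc3)nc2-c2ccccc2)cc1`) gives 52000 nM and compound 2 (`FC(F)(F)c1ccc(NCc2cn(-c3ccccc3)nc2-c2ccc(Br)cc2)cc1`) gives 28000 nM, so these two values lie within the usual scatter of each other. Compound 3 (`Cc1ccc(NCc2cn(-c3ccccc3)nc2-c2ccccc2)cc1`) differs from compound 1 in one place, with methyl in place of bromo on an aromatic carbon. Within the data shown here, no measured pair here shows what a single change does, so this expectation rests on little evidence. In this assay, the expected step of a 1.0-fold lower number from compound 1 to compound 3 (0.02 log units; within the scatter) is none beyond the scatter, in either direction. For compound 3 the estimated value is 50000 nM, with an expected range from 22000 nM to 100000 nM.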

Compound 3, half-maximal cytotoxic concentration: > 100000 nM
Compound 3 was reported as a limit (the forecaster's own chance of this, stated with the estimate: 20%); at least 2.0-fold (0.30 log units) between middle value and limit.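

Compound 3 is reported as a limit, > 100000 nM, and not as a number. In this assay, methyl in place of bromo on this aromatic carbon, para to a large group, gives the first single-change reading: an at least 1.9-fold higher number from compound 1 to compound 3 (0.28 log units; that floor lies within the scatter). This reading points towards no greater toxicity in this test, yet it sets only a floor on the step: the limit of > 100000 nM in this assay, at which 1 of the 3 values shown sits.

Going by these compounds, how far the true step runs past that floor stays open. So does the effect of other groups at this position, such as an amine or a carboxylic acid.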